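One methoxy fewer on the amide aryl of compound 2

The source may hold more compounds than are shown below. What is called first, only, known or untested is meant among the compounds shown, and "the series" means these compounds.

Measured so far:
compound 1 `COc1ccc(Cl)cc1N(CC(=O)Nc1cccc2ccccc12)S(=O)(=O)c1ccccc1` — 17400 nM
compound 2 `COc1ccc(NC(=O)CN(c2cc(Cl)ccc2OC)S(=O)(=O)c2ccccc2)cc1OC` — > 20000 nM
compound 3 `COc1ccc(Cl)cc1N(CC(=O)Nc1ccc(C(F)(F)F)cc1)S(=O)(=O)c1ccccc1` — 3750 nM

In a functional assay on SH-SY5Y cells (Homo sapiens), read by MTT assay, with a stated time of 24 h (on this read-out higher numbers stand for an effect only at larger amounts of compound and lower numbers for an effect already at smaller amounts), compound 2 returns only a limit, > 20000 nM, as recorded at the limit of > 20000 nM in this assay, at which 1 of the 3 values shown sits. Among the three measured compounds it therefore stands at the weak end of what is shown: the step of an at least 1.1-fold higher number from compound 1 to compound 2 (0.06 log units; that floor lies within the scatter) lies within the scatter, while the step of an at least 5.3-fold lower number from compound 2 to compound 3 (0.72 log units; beyond the scatter) is beyond it. The step of a 4.6-fold lower number from compound 1 to compound 3 (0.67 log units; beyond the scatter) shows the same order for compound 1 against compound 3.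

Compound 4 `COc1ccc(NC(=O)CN(c2cc(Cl)ccc2OC)S(=O)(=O)c2ccccc2)cc1` differs from compound 2 in one place: hydrogen in place of methoxy on an aromatic carbon. Going by the values given here, none of the measured steps removes a methoxy group; all three exchange the whole aryl group on the amide-type nitrogen. The nearest comparison is the small step of an at least 1.1-fold higher number from compound 1 to compound 2 (0.06 log units; that floor lies within the scatter), which suggests that aryl groups of this kind move the read-out little. A change within the scatter, or at most a modest lowering, is therefore expected.

For compound 4 the expected value is about 18000 nM, and the expected range runs from 6000 nM to 40000 nM. The step of an at least 1.1-fold lower number from compound 2 to compound 4 (0.04 log units; that floor lies within the scatter) is expected to stay within or near the scatter.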

Compound 4, half-maximal effective concentration: 16200 nM
Estimate against measurement, compound 4: 1.1-fold (0.05 log units) above, and the stated range covers the measured number.
By their numbers in this assay, from the lowest: compound 3; then compounds 4 and 1 (each within the scatter of the next). At a limit, above all of these: compound 2.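

Compound 2 stands only at a limit: the limit of > 20000 nM in this assay, at which 1 of the 4 values shown sits. From the compounds shown here alone, removing one methoxy to leave 4-methoxyphenyl gives, in this assay, the step of an at least 1.2-fold lower number from compound 2 to compound 4 (0.09 log units; that floor lies within the scatter), so only a floor within the scatter can be read for this position, and the true size of the change remains unknown. The step of a 1.1-fold lower number from compound 1 to compound 4 (0.03 log units; within the scatter) does not separate the 4-methoxyphenyl amide from the naphthalen-1-yl amide, whereas the step of a 4.3-fold higher number from compound 3 to compound 4 (0.64 log units; beyond the scatter) shows that a single-group exchange on this aryl ring, methoxy in place of trifluoromethyl, can carry a change beyond the scatter.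

Going by these compounds, what a hydroxy group, an amine or a fluorine at the freed aromatic carbon would do remains open. So does whether trifluoromethyl would give a similar number at that carbon.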